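Acetoxy for methyl on the lactone core

This account rests on a few compounds, and the source may have more. Where it says the series, first, only, none or still open, it means among the compounds named here.

Compound 1 `CC(=O)O[C@@H]1OC(=O)[C@](C)(C(C)=O)[C@@H]1C` and compound 2 `CC(=O)O[C@@H]1OC(=O)[C@@](C)(C(C)=O)[C@@H]1C` share every atom and bond and differ only in configuration as drawn. Among the compounds with values here, in a functional assay on HT-29 cells (Homo sapiens) for cytotoxicity, read by MTT assay (a lower number here means a stronger inhibitor, a higher number a weaker inhibitor), compound 1 gives 5000 nM and compound 2 gives 12000 nM, the higher of the two numbers measured so far; the only measured step is a 2.4-fold higher number from compound 1 to compound 2 (0.38 log units; beyond the scatter), and the difference between them is one of configuration (the fact that compounds 1 and 2 differ only in the configuration as drawn).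

Compound 3 `CC(=O)O[C@@H]1OC(=O)[C@@](OC(C)=O)(C(C)=O)[C@@H]1C` changes the core of compound 2 by acetoxy in place of methyl on a saturated ring carbon. Within the data shown here, no measured step touches this kind of change: the single step from compound 1 to compound 2 concerns a stereocentre, not a group exchange, so it offers no direct guide to the size or direction of this one. The step is therefore expected to be a 1.3-fold higher number from compound 2 to compound 3 (0.10 log units; within the scatter), with a wide range allowed.

In this assay compound 3 is estimated at 15000 nM, expected between 4000 nM and 60000 nM.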

Compound 3, half-maximal inhibitory concentration: > 50000 nM
Compound 3 gave a limit, no number; the forecaster's own chance of this, stated with the estimate: 10%; middle value at least 3.3-fold (0.52 log units) away from the limit.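

In this assay, acetoxy in place of methyl on the saturated ring carbon gives an at least 4.1-fold higher number from compound 2 to compound 3 (0.61 log units; beyond the scatter), so a group exchange at this carbon moves the series towards a weaker inhibitor. The earlier step, a 2.4-fold higher number from compound 1 to compound 2 (0.38 log units; beyond the scatter), concerned only the configuration at this same carbon and gave no reading of a group exchange there. Compound 3 gives > 50000 nM, which is a limit of the assay and not a number, so the step has a lower bound but no upper one: the limit of > 50000 nM in this assay, at which 1 of the 3 values shown sits.

The compounds shown leave open how far compound 3 actually lies from compound 2, and whether the loss tracks acetoxy specifically. A hydroxyl group or an ethyl chain on this carbon would test that, as would acetoxy in the opposite configuration.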